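N-methyl to N-(3-methoxybenzyl) on the cyclohexyl amide

The source may report more compounds than this note shows. Statements on the series, on what has been measured and on what is new or still open speak of the compounds shown alone.

Compound 1 `COC(=O)/C=C/c1cccc(N(Cc2ccc(-c3ccc(N(C)C)cc3)cc2)C(=O)NC(C)C)c1` gives 162 nM in an assay on isolated protein with Bile acid receptor (Homo sapiens) as the target; a higher number here means that more compound is needed for the effect, a lower number that less compound is needed. Compound 2 `COC(=O)/C=C/c1cccc(N(C)C(=O)C2CCCCC2)c1` shows only a limit in this assay, > 1000 nM; it sits at the limit of > 1000 nM in this assay, at which 1 of the 2 values shown sits. Compound 3 `COC(=O)/C=C/c1cccc(N(Cc2cccc(OC)c2)C(=O)C2CCCCC2)c1` differs from compound 2 by 3-methoxyphenyl in place of hydrogen on a saturated chain carbon bound to an amide-type nitrogen. Among the compounds with values here, no measured pair covers this change directly. Because compound 1 gives 162 nM while carrying a benzyl-type group on its amide-type nitrogen, a gain in this assay is expected here, estimated as an at least 2.0-fold lower number from compound 2 to compound 3 (0.30 log units; that floor lies within the scatter). Compound 3 is therefore expected to reach about 500 nM, with a likely range from 120 nM to 3000 nM.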

Compound 3, half-maximal effective concentration: > 1000 nM
Compound 3: no number, only a limit; the forecaster's own chance of this, stated with the estimate: 35%; at least 2.0-fold (0.30 log units) between middle value and limit.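

Compound 2 and compound 3 both sit at a limit, so no step can be read between them: the limit of > 1000 nM in this assay, at which 2 of the 3 values shown sit.

Left open is whether 3-methoxyphenyl in place of hydrogen changes the value in this assay at all.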